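Esterifying a Carboxylic Acid on a Kinase Inhibitor

A few compounds are considered here, and "the series" means these few. Any claim that something is new, unique, unknown or untested is made for them only; others in the source may bear on it.

Measured compounds:
compound 1, `Cc1ccc2c(c1)CC(C(=O)Nc1ccc(-c3cn[nH]c3)cc1)CO2`: 10 nM
compound 2, `O=C(O)c1ccc2c(c1)CC(C(=O)Nc1ccc(-c3cn[nH]c3)cc1)CO2`: 30 nM

Both were tested in an assay on isolated protein for inhibition of Rho-associated protein kinase 2 (Homo sapiens); a lower number here means a stronger inhibitor, a higher number a weaker inhibitor. Within the data shown here, of the two numbers, compound 2 has the higher one; its only neighbour, compound 1, sits lower, and the step of a 3.0-fold higher number from compound 1 to compound 2 (0.48 log units; beyond the scatter) came with carboxy in place of methyl on an aromatic carbon.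

Compound 3, `COC(=O)c1ccc2c(c1)CC(C(=O)Nc1ccc(-c3cn[nH]c3)cc1)CO2`, has not yet been measured. It differs from compound 2 by methyl in place of hydrogen on an oxygen next to a carbonyl group, so the carboxy becomes methoxycarbonyl. Among the measured compounds shown here, no measured pair shows this exact change. For the measured compounds named here, the one related step, a 3.0-fold higher number from compound 1 to compound 2 (0.48 log units; beyond the scatter), shows that exchanging methyl for carboxy on that aromatic carbon cost only a modest amount, so variation there has so far been tolerated. Capping the acid as its methyl ester is therefore expected to move the number little, a 1.5-fold lower number from compound 2 to compound 3 (0.18 log units; within the scatter), with no step beyond the scatter anticipated. Compound 3 is estimated at 20 nM, within a range from 7 nM to 60 nM.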

Compound 3, half-maximal inhibitory concentration: 10 nM
Compound 3: middle estimate off by 2.0-fold (0.30 log units), on the high side, within the range that was stated.
By their numbers in this assay, from the lowest: compounds 1 and 3 (each within the scatter of the next); then compound 2.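

In this assay, placing a methyl on the oxygen of the carboxy group gives a 3.0-fold lower number from compound 2 to compound 3 (0.48 log units; beyond the scatter), so the higher number of compound 2 does not carry over to every carbonyl-bearing group on this aromatic carbon. Compared with the methyl group of compound 1, methoxycarbonyl shows no change at the digits printed from compound 1 to compound 3 (within the scatter), so among these three compounds, only the carboxy group of compound 2 stands apart, while the methyl and methoxycarbonyl groups cannot be told apart in this measurement. Nothing available explains why the free carboxy group differs from its methyl ester.

From the compounds shown here alone, it remains open whether a longer ester such as ethoxycarbonyl, an amide or an amine on this aromatic carbon would sit with compound 1 and compound 3 or with compound 2. These compounds also vary in only this one place, so they say nothing about changes elsewhere on the shared core.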